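The compounds below may be only part of what the source reports. "The series", "measured", "known", "first", "only" and "open" are said of these compounds alone.

Three compounds of this series have been measured in an assay on Sf9 cells for inhibition of serine/threonine-protein kinase 4 (Homo sapiens), read by luminescence and ADP-Glo, with a stated time of 1 h, in the presence of a further agent that is not named here; on this read-out higher numbers stand for weaker inhibition and lower numbers for stronger inhibition:

Compound 1, `CCC1C(=O)N(C)c2cnc(Nc3ccc(S(N)(=O)=O)cc3)nc2N1C`, gives 479 nM.
Compound 2, `CN1C(=O)C(CC2CC2)N(C)c2nc(Nc3ccc(S(N)(=O)=O)cc3)ncc21`, gives 211 nM.
Compound 3, `CN1C(=O)C(c2cccc(F)c2)N(C)c2nc(Nc3ccc(S(N)(=O)=O)cc3)ncc21`, gives 134 nM.

Compound 2 stands second highest of these three numbers. Its nearest neighbour is compound 3, separated by a 1.6-fold lower number from compound 2 to compound 3 (0.20 log units; within the scatter), a gap that lies within the scatter of repeated measurements. Its furthest neighbour is compound 1, and the step of a 2.3-fold lower number from compound 1 to compound 2 (0.36 log units; beyond the scatter) lies beyond the scatter.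

The next compound, compound 4, `CN1C(=O)C(c2ccccc2C(F)(F)F)N(C)c2nc(Nc3ccc(S(N)(=O)=O)cc3)ncc21`, has not yet been measured. It differs from compound 2 in one place: 2-(trifluoromethyl)phenyl in place of cyclopropylmethyl on a saturated ring carbon.

Going by the values given here, two measured steps bear on this change. Putting an aromatic ring on the same saturated ring carbon in place of cyclopropylmethyl gave a 1.6-fold lower number from compound 2 to compound 3 (0.20 log units; within the scatter), within the scatter, and in place of ethyl gave a 3.6-fold lower number from compound 1 to compound 3 (0.55 log units; beyond the scatter), a modest gain. Among the compounds with values here, no measured compound carries a trifluoromethyl group on that aromatic ring, so the contribution of that group is unknown. On this basis the number for compound 4 is expected to be close to that of compound 2, with at most a small step toward a lower number, a 1.3-fold lower number from compound 2 to compound 4 (0.12 log units; within the scatter). Compound 4 is therefore estimated at 160 nM, with a range from 60 nM to 420 nM.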

Compound 4, half-maximal inhibitory concentration: 56 nM
The estimate for compound 4 lay 2.9-fold (0.46 log units) above the measured number, and the stated range ends above it.
By their numbers in this assay, from the lowest: compound 4; then compounds 3 and 2 (each within the scatter of the next); then compound 1.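

The result shows that an aromatic ring on this saturated ring carbon can give a step beyond the scatter relative to cyclopropylmethyl in this assay, with a 3.8-fold lower number from compound 2 to compound 4 (0.58 log units; beyond the scatter), whereas the 3-fluorophenyl group of compound 3 had stayed within the scatter of compound 2. Going by these compounds alone, it also shows that the substitution on that aromatic ring matters at this position, since 2-(trifluoromethyl)phenyl in place of 3-fluorophenyl gives a 2.4-fold lower number from compound 3 to compound 4 (0.38 log units; beyond the scatter), and the earlier compounds held only one aromatic group here. The full span seen so far at this carbon now runs from ethyl to 2-(trifluoromethyl)phenyl, with an 8.6-fold lower number from compound 1 to compound 4 (0.93 log units; beyond the scatter), although no measured property of these groups is available to explain the result.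

Compounds 3 and 4 differ in both the substituent and its place on the aromatic ring, so the shown compounds cannot separate the contribution of trifluoromethyl from that of its location. Going by these compounds, how an unsubstituted phenyl, a 3-(trifluoromethyl)phenyl or a 2-fluorophenyl group would compare at this carbon remains open, as does whether a pyridine ring or an amine-bearing chain would be tolerated there.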